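This account rests on a few compounds, and the source may have more. Where it says the series, first, only, none or still open, it means among the compounds named here.

Measured so far in a functional assay on the whole organism for antagonist activity, with Mus musculus as the target; on this read-out lower numbers stand for an effect already at smaller amounts and higher numbers for an effect only at larger amounts of compound:
compound 1 `CC(C#CCn1ccnc1)N1CCCC1=O` gives 2 mg/kg
compound 2 `Cc1cncn1CC#CC(C)N1CCCC1=O` gives 0.45 mg/kg
compound 3 `CCOC(=O)N(C)C(C)C#CCn1ccnc1` gives 54 mg/kg

Compound 2 differs from compound 1 by methyl in place of hydrogen on an aromatic carbon; the result was a 4.4-fold lower number from compound 1 to compound 2 (0.65 log units; beyond the scatter). Compound 3 sits on another core, and the difference between the two cores is not broken down here; in this assay its number is the highest of the three measured.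

Compound 4 `CCOC(=O)N(C)C(C)C#CCn1cncc1C` has not been measured. It differs from compound 3 by methyl in place of hydrogen on an aromatic carbon, the same change as from compound 1 to compound 2, at a place described in the same words. The expected step is a 4.2-fold lower number from compound 3 to compound 4 (0.62 log units; beyond the scatter), and that expectation rests on the measured step of a 4.4-fold lower number from compound 1 to compound 2 (0.65 log units; beyond the scatter), applied to compound 3 and its value 54 mg/kg. Compound 4 is therefore estimated at 13 mg/kg in this assay, expected between 5 mg/kg and 35 mg/kg.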

Compound 4, dose for half-maximal effect: 9.7 mg/kg
Estimate against measurement, compound 4: 1.3-fold (0.13 log units) above; the range from low to high includes it.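

On the core of compound 3, going from 1H-imidazol-1-yl to 5-methyl-1H-imidazol-1-yl gives a 5.6-fold lower number from compound 3 to compound 4 (0.75 log units; beyond the scatter) in this assay. The methyl step carries across the two cores shown with no difference in size that can be told apart: the same change on two cores in this assay, a 4.4-fold lower number (0.65 log units; beyond the scatter) from compound 1 to compound 2 and a 5.6-fold lower number (0.75 log units; beyond the scatter) from compound 3 to compound 4, 1.3-fold (0.10 log units) apart, within the scatter of two such steps. This supports carrying the change between these two cores in this assay only; it does not show that the step would hold on a third core, and it does not explain why the number falls.

Still open, on these data alone, is whether a longer chain or a trifluoromethyl in place of that methyl gives a step of similar size. Also open, as far as these compounds go, is whether a methyl elsewhere on the ring does the same.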